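This account rests on a few compounds, and the source may have more. Where it says the series, first, only, none or still open, it means among the compounds named here.

Compound 1 `COc1ccc(Cc2nnc(NC(=O)/C(C#N)=C/c3ccccc3OS(=O)(=O)c3ccc(F)cc3)s2)cc1`: 25%
Compound 2 `Cc1ccc(Cc2nnc(NC(=O)/C(C#N)=C/c3ccccc3OS(=O)(=O)c3ccc([N+](=O)[O-])cc3)s2)cc1`: 17%

In a functional assay on HL-60 cells (Homo sapiens) for inhibition, read by CCK-8 assay, with a stated time of 48 h, tested at 20 uM (on this read-out higher numbers stand for more inhibition of growth at the one concentration tested and lower numbers for less inhibition of growth), compound 2 gives 17%, which lies within the scatter of compound 1 at 25%. Compound 3 `Cc1ccc(Cc2nnc(NC(=O)/C(C#N)=C/c3ccccc3OS(=O)(=O)c3ccc(F)cc3)s2)cc1` has fluoro in place of nitro on an aromatic carbon, para to a large group: fluoro in place of nitro on an aromatic carbon. For the measured compounds named here, no measured pair differs in one place, so the data show no step of this kind. In this assay, no change beyond the scatter is expected for this replacement. The expected a number 5 percentage points higher from compound 2 to compound 3 (within the scatter) is therefore small. Compound 3 is estimated at 22%, within an expected range of 10% to 36%.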

Compound 3, percent growth inhibition at one concentration: 11%
For compound 3 the middle estimate is 11 percentage points above the measured one; low and high end bracket the measured number.
By their numbers in this assay, from the lowest: compounds 3, 2 and 1 (each within the scatter of the next, the first and the last beyond it).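

In this assay the first one-place comparisons become readable: fluoro in place of nitro on an aromatic carbon, para to a large group, gives a number 6 percentage points lower from compound 2 to compound 3 (within the scatter), so this replacement leaves no change that can be told from the scatter. Methyl in place of methoxy on an aromatic carbon gives a number 14 percentage points lower from compound 1 to compound 3 (beyond the scatter), a modest step that goes beyond it. Nothing available explains either step.

On these data alone, whether an amine or a carboxylic acid in place of fluoro would alter growth inhibition remains open. So does the effect of a longer chain in place of methyl.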